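A few compounds are considered here, and "the series" means these few. Any claim that something is new, unique, unknown or untested is made for them only; others in the source may bear on it.

Measured so far in a functional assay on KYSE-450 cells (Homo sapiens) for inhibition, read by MTT assay, with a stated time of 48 h; on this read-out higher numbers stand for weaker inhibition and lower numbers for stronger inhibition:
compound 1 `C#CC(=O)N(Cc1ccc(OC)c(O)c1)c1cc(OC)c(OC)c(OC)c1` gives 570 nM
compound 2 `COc1ccc(CNc2cc(OC)c(OC)c(OC)c2)cc1F` gives 46200 nM
compound 3 `C/C=C/C(=O)N(Cc1ccc(OC)cc1)c1cc(OC)c(OC)c(OC)c1` gives 420 nM

Compound 1 holds the second highest of the three numbers. Compound 3 sits nearest to it, with a gap that stays within the usual scatter, so no order between compound 1 and compound 3 can be read from these two numbers. Compound 2 lies furthest away, with a far higher number, a gap well beyond the scatter; compound 2 carries no carbonyl on its nitrogen, whereas compound 1 and compound 3 both do.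

The next compound is compound 4 `COc1ccc(CN(C(=O)C(C)Br)c2cc(OC)c(OC)c(OC)c2)cc1O`. Its difference from compound 1 is 1-bromoethyl in place of ethynyl on a carbonyl carbon. Compound 4 keeps the carbonyl on the amide-type nitrogen that compound 2 lacks, so the large drop seen for compound 2 is not expected here. Among the compounds with values here, no step between measured compounds shows what this exchange does on its own. In this assay the expected step is a 1.9-fold higher number from compound 1 to compound 4 (0.29 log units; within the scatter), modest and toward a higher number, near the edge of the scatter. Compound 4 is therefore estimated at 1100 nM, with a range from 300 nM to 4500 nM.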

Compound 4, half-maximal inhibitory concentration: 160 nM
Beside the measured number, compound 4's estimate is 6.9-fold (0.84 log units) above it; measured number outside the range, below it.
By their numbers in this assay, from the lowest: compound 4; then compounds 3 and 1 (each within the scatter of the next); then compound 2.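

In this assay, within the data shown here, the exchange of ethynyl for 1-bromoethyl on a carbonyl carbon gives a 3.6-fold lower number from compound 1 to compound 4 (0.55 log units; beyond the scatter), the first step that isolates this position, and it shows that the group here changes the number on its own. The triple bond is therefore not needed to reach a number at this level, since 1-bromoethyl, which has none, gives the lower number of this pair. Nothing on hand accounts for the direction or the size of this step.

Compound 3 differs from compound 4 in more than one place, so the group on its carbonyl cannot be ranked against 1-bromoethyl from this pair. Going by these compounds, whether the bromine matters in itself remains open: an ethyl group or a 1-chloroethyl group at this position would separate the halogen from the saturated carbon chain.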